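Extending the alkyne ester chain on a caffeic ester core

A few compounds are considered here, and "the series" means these few. Any claim that something is new, unique, unknown or untested is made for them only; others in the source may bear on it.

Compound 1 `C#CCCOC(=O)/C=C/c1ccc(OC(C)=O)c(OC(C)=O)c1` carries the shortest of three alkyne esters on the shared core. In an assay on isolated protein for inhibition of Polyunsaturated fatty acid 5-lipoxygenase (Homo sapiens), read by HPLC, with a stated time of 15 min (a higher number here means a weaker inhibitor, a lower number a stronger inhibitor), compound 1 gives only a limit, > 10000 nM. Compound 2 `C#CCCCCOC(=O)/C=C/c1ccc(OC(C)=O)c(OC(C)=O)c1` lengthens that ester. In this assay compound 2 likewise gives a limit, > 10000 nM. Compound 3 `C#CCCCCCOC(=O)/C=C/c1ccc(OC(C)=O)c(OC(C)=O)c1` lengthens it again. In this assay compound 3 also returns a limit, > 10000 nM, so compound 3 stands at the same limit as its two companions and no ordering among them can be read. The steps between them are correspondingly unreadable: a step that the two limits leave unreadable from compound 1 to compound 2, a step that the two limits leave unreadable from compound 1 to compound 3 and a step that the two limits leave unreadable from compound 2 to compound 3. All three values sit at the limit of > 10000 nM in this assay, at which 3 of the 3 values shown sit.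

Compound 4 `C#CCCCCCCCCOC(=O)/C=C/c1ccc(OC(C)=O)c(OC(C)=O)c1` continues the series with pent-4-yn-1-yl in place of ethynyl on a saturated chain carbon, five bonds along the chain from an oxygen next to a carbonyl group. The three measured steps bear on this change, since each of them also lengthens the same ester chain, and none of them reveals any movement in potency that the assay could report. The expected step, a step that the limit leaves unreadable from compound 3 to compound 4, is therefore none that the numbers can show, and a further limit is the most probable outcome. Compound 4 is estimated at 20000 nM, between 5000 nM and 100000 nM.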

Compound 4, half-maximal inhibitory concentration: > 10000 nM
Compound 4 was reported as a limit; the forecaster's own chance of this, stated with the estimate: 85%; the middle value lies beyond the limit too.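

In this assay compound 4 gives > 10000 nM, again a limit. Its steps from compound 1, compound 2 and compound 3 therefore cannot be read: the limit of > 10000 nM in this assay, at which 4 of the 4 values shown sit.

The compounds shown leave open whether any alkyne ester on the shared core reaches a readable value in this assay, and how chain length would then bear on potency.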